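Removing one trifluoromethyl from the urea aryl of compound 1

The source may hold more compounds than are shown below. What is called first, only, known or untested is meant among the compounds shown, and "the series" means these compounds.

For the measured compounds named here, compound 1 `O=C(Nc1cccc(-n2cc(-c3ccncc3)c(-c3ccc(Cl)c(O)c3)n2)c1)Nc1cc(C(F)(F)F)cc(C(F)(F)F)c1` holds the only numeric reading among the three measured compounds: in a functional assay on A498 cells (Homo sapiens) for inhibition, read by sulforhodamine B assay, with a stated time of 48 h (on this read-out lower numbers stand for higher toxicity in this test and higher numbers for lower toxicity in this test), compound 1 gives 16000 nM. Compound 2 `COc1cc(-c2nn(-c3cccc(NC(=O)Nc4ccc(Cl)c(C(F)(F)F)c4)c3)cc2-c2ccncc2)ccc1Cl` reaches only a limit of this assay, where compound 2 gives > 32500 nM. Compound 3 `COc1cc(-c2nn(-c3cccc(NC(=O)c4ccccc4)c3)cc2-c2ccncc2)ccc1Cl` likewise stops at a limit of this assay, compound 3 giving > 100000 nM. Going by the values given here, the one step between measured compounds, a step that the two limits leave unreadable from compound 2 to compound 3, cannot be read; both of its ends sit at limits, the limit of > 32500 nM in this assay, at which 1 of the 3 values shown sits, for compound 2 and the limit of > 100000 nM in this assay, at which 1 of the 3 values shown sits, for compound 3.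

Compound 4 `O=C(Nc1cccc(-n2cc(-c3ccncc3)c(-c3ccc(Cl)c(O)c3)n2)c1)Nc1cccc(C(F)(F)F)c1` differs from compound 1 in a single place: hydrogen in place of trifluoromethyl on an aromatic carbon. Among the compounds with values here, no measured step touches a trifluoromethyl on this urea aryl, and the only step available is unreadable; the expectation for compound 4 therefore rests on compound 1 alone, whose reading of 16000 nM is the anchor. The change is small, and compound 4 is expected to lie near compound 1 or somewhat weaker, a step of a 1.6-fold higher number from compound 1 to compound 4 (0.19 log units; within the scatter), with a real chance that this assay again reports only a limit. Compound 4 is accordingly estimated at 25000 nM, within a range from 8000 nM to 80000 nM.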

Compound 4, concentration lethal to 50% of the cells: > 32500 nM
Compound 4 gave a limit, no number (the forecaster's own chance of this, stated with the estimate: 30%); middle value at least 1.3-fold (0.11 log units) from the limit.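

In this assay, hydrogen in place of trifluoromethyl on this carbon of the urea aryl gives an at least 2.0-fold higher number from compound 1 to compound 4 (0.30 log units; that floor lies within the scatter). For the compounds shown here, this is the first step that can be read at this position, and it is a floor rather than a size: it shows only that the single numeric reading held by compound 1 does not carry over once this trifluoromethyl leaves, while the floor itself does not clear the usual scatter. The result for compound 4 is a limit and not a number: the limit of > 32500 nM in this assay, at which 2 of the 4 values shown sit.

On these data alone, the true size of the step stays open, since the distance of compound 4 from its limit cannot be told, and the step may lie within the scatter or well beyond it. Also open, as far as these compounds go, is whether a nitrile or an amine in place of this trifluoromethyl, or a trifluoromethyl kept on this carbon with the other one replaced by hydrogen, would give a numeric reading in this assay and so fix what this position contributes.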